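Working notes: the step from compound 3 to compound 4

The source may hold more compounds than are shown below. What is called first, only, known or untested is meant among the compounds shown, and "the series" means these compounds.

In a functional assay for inhibition, with Homo sapiens as the target (on this read-out lower numbers stand for stronger inhibition and higher numbers for weaker inhibition), compound 1 `CC(C)(C)Sc1c(CC(C)(C)C(=O)O)n(Cc2ccc(Cl)cc2)c2ccc(OCc3cc4ccccc4cn3)cc12` gives 3 nM and compound 2 `COc1ccc2nc(COc3ccc4c(c3)c(SC(C)(C)C)c(CC(C)(C)C(=O)O)n4Cc3ccc(Cl)cc3)sc2c1` gives 8 nM while compound 3 `CC(C)(C)Sc1c(CC(C)(C)C(=O)O)n(Cc2ccc(Cl)cc2)c2ccc(OCc3cccc(Cl)n3)cc12` gives 3 nM on the same read-out. Compound 3 thus stands level with compound 1 at the lowest number of the three, and compound 2 lies above both.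

Among the compounds with values here, compound 4 `CC(COc1ccc2c(c1)c(SC(C)(C)C)c(CC(C)(C)C(=O)O)n2Cc1ccc(Cl)cc1)c1ccccn1` has no measurement yet. Its difference from compound 3 is 1-(pyridin-2-yl)ethyl in place of 6-chloropyridin-2-yl on a saturated chain carbon bound to an oxygen on an aromatic ring with 1-(pyridin-2-yl)ethyl in place of 6-chloropyridin-2-yl on a saturated chain carbon bound to an oxygen on an aromatic ring.

Three measured steps fall at that same place. They are no change at the digits printed from compound 1 to compound 3 (within the scatter) and a 2.7-fold higher number from compound 1 to compound 2 (0.43 log units; beyond the scatter) and a 2.7-fold lower number from compound 2 to compound 3 (0.43 log units; beyond the scatter) as the group there is exchanged. Across these three groups the number has moved only modestly. Within the data shown here, no measured compound carries a 1-(pyridin-2-yl)ethyl group, so these steps bear on the new group only loosely.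

A modest move to a higher number is therefore expected in this assay and the expected change is a 2.7-fold higher number from compound 3 to compound 4 (0.43 log units; beyond the scatter) with a wide margin on either side. For compound 4 the estimated value is 8 nM with an expected range from 3 nM to 25 nM in this series.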

Compound 4, half-maximal inhibitory concentration: 4 nM
Compound 4: middle estimate off by 2.0-fold (0.30 log units), on the high side, within the range that was stated.
By their numbers in this assay, from the lowest: compounds 1, 3, 4 and 2 (each within the scatter of the next, the first and the last beyond it).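

In this assay, the place on a saturated chain carbon bound to an oxygen on an aromatic ring takes 1-(pyridin-2-yl)ethyl in place of 6-chloropyridin-2-yl, with a 1.3-fold higher number from compound 3 to compound 4 (0.12 log units; within the scatter), so this exchange, which also removes the chlorine, leaves no change that can be told from the scatter. Within the data shown here, the new group also lies within the scatter of the other two groups, with a 1.3-fold higher number from compound 1 to compound 4 (0.12 log units; within the scatter) and a 2.0-fold lower number from compound 2 to compound 4 (0.30 log units; within the scatter), which makes it the first group here that is not separated from any other, whereas 6-methoxy-1,3-benzothiazol-2-yl and the two lowest groups stood apart beyond the scatter. No measurement is available to explain why these groups give such similar numbers.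

The exchange alters the ring substituent and the attachment together, so the compounds shown do not separate the loss of chlorine from the arrival of the ethyl unit, and a 6-chloropyridin-2-yl carried on the same ethyl unit would be the direct test. Also open, from the compounds shown here alone, is how far this place tolerates other groups, such as an amine or a carboxylic acid on the pyridine ring, or a longer chain in place of the ethyl unit.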